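A few compounds are considered here, and "the series" means these few. Any claim that something is new, unique, unknown or untested is made for them only; others in the source may bear on it.

Measured compounds:
Compound 1, `Cc1ccc(-c2nc3cc(Cl)ccc3[nH]2)nc1`, gives -5%.
Compound 2, `Cc1cccc(-c2nc3cc(O)ccc3[nH]2)n1`, gives 6%.

Both compounds were tested in a functional assay on the whole organism with Rattus norvegicus as the target, read by paw edema, with a stated time of 3 h, at a dose of 100 mg/kg by the oral route; on this read-out higher numbers stand for more inhibition at the one dose given (going by the name of the read-out) and lower numbers for less inhibition. Compound 1 stands lowest of the two numbers shown, with -5%. The nearest number is that of compound 2, which lies higher by a gap that is beyond the usual scatter, so the two readings do differ, though both remain near the bottom of the scale. Going by the values given here, no step between measured compounds that differ in one place is available, so nothing in the measured set shows how a small change on the shared core moves the read-out.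

Compound 3, `CCc1ccc(-c2nc3cc(Cl)ccc3[nH]2)nc1`, has not been measured. Compared with compound 1 the change is methyl in place of hydrogen on a saturated chain carbon bound to an aromatic carbon; seen one bond further out, it reads as methyl to ethyl. Among the compounds with values here, with no comparable step in hand, the step from compound 1 to compound 3 is expected to be a number 5 percentage points higher from compound 1 to compound 3 (within the scatter), that is, none beyond the scatter, in either direction. Compound 3 is therefore estimated at 0%, with a range from -15% to 15%.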

Compound 3, a percentage reported as inhibition, in the whole organism at one dose (the size of the read-out at that dose, not a potency): -2%
Compound 3: middle estimate off by 2 percentage points, on the high side, within the range that was stated.
By their numbers in this assay, from the lowest: compounds 1, 3 and 2 (each within the scatter of the next, the first and the last beyond it).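

In this assay, going by these compounds alone, the change of methyl in place of hydrogen on a saturated chain carbon bound to an aromatic carbon, which reads as methyl to ethyl, gives the first step on a single change, a number 3 percentage points higher from compound 1 to compound 3 (within the scatter), and so the set now has one direct comparison on the shared core. At this place, the added methyl therefore moves the read-out by no more than repeated measurements would, and at this one oral dose the ethyl compound stays in the same low range as the methyl compound. No independent measurement bears on this result, so the step stands without any explanation.

Going by these compounds, whether a longer chain such as propyl, or an amine or a carboxylic acid carried on this chain, would lift the read-out clear of the scatter remains open, since a step from methyl to ethyl says nothing about those groups. Also open, on these data alone, is whether the same step would stay as small on a core carrying a methoxy group in place of the chlorine of compound 1.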